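A few compounds are considered here, and "the series" means these few. Any claim that something is new, unique, unknown or untested is made for them only; others in the source may bear on it.

Working notes, cytotoxicity series

Compound 3 `Cc1cn([C@@H]2O[C@H](CO[Si](C)(C)C(C)(C)C)[C@@]3(OS(=O)(=O)C=C3NC(=O)c3ccccc3)[C@H]2O[Si](C)(C)C(C)(C)C)c(=O)n(C)c1=O` stands on a limit in a functional assay on HEL cells (Homo sapiens) for cytotoxicity, read by microscopy; a higher number here means that more compound is tolerated, a lower number that less compound is tolerated: compound 3 gives >= 3200 nM, and this is a limit of the assay, not a number. The two neighbours with full numbers are compound 1 `Cc1cn([C@@H]2O[C@H](CO[Si](C)(C)C(C)(C)C)[C@@]3(OS(=O)(=O)C=C3NCC(=O)O)[C@H]2O[Si](C)(C)C(C)(C)C)c(=O)n(C)c1=O`, which gives 300000 nM, and compound 2 `Cc1cn([C@@H]2O[C@H](CO[Si](C)(C)C(C)(C)C)[C@@]3(OS(=O)(=O)C=C3NCC(=O)C(=O)O)[C@H]2O[Si](C)(C)C(C)(C)C)c(=O)n(C)c1=O`, which gives 400000 nM. The step of a 1.3-fold higher number from compound 1 to compound 2 (0.12 log units; within the scatter) stays within the scatter. The steps a step that the limit leaves unreadable from compound 1 to compound 3 and a step that the limit leaves unreadable from compound 2 to compound 3 cannot be sized, since the limit of >= 3200 nM in this assay, at which 1 of the 3 values shown sits, caps what compound 3 shows.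

Compound 4 `CCNC(=O)NC1=CS(=O)(=O)O[C@@]12[C@@H](CO[Si](C)(C)C(C)(C)C)O[C@@H](n1cc(C)c(=O)n(C)c1=O)[C@@H]2O[Si](C)(C)C(C)(C)C` differs from compound 3 at the carbonyl carbon: ethylamino in place of phenyl on a carbonyl carbon. For the measured compounds named here, no measured pair changes the group on this carbonyl carbon, and the only two steps that end at compound 3 are unreadable, so the numbers give no direction for this change. What can be said is that compound 3 is tolerated at its limit and that compound 1 and compound 2 are tolerated far into the high range.

Compound 4 is therefore expected, with wide uncertainty, at 30000 nM, between 3200 nM and 400000 nM. The step that the limit leaves unreadable from compound 3 to compound 4 is then the expected outcome, with a fair chance that compound 4 again reports only a limit.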

Compound 4, minimum cytotoxic concentration: >= 3200 nM
Compound 4 ended at the assay's limit; the forecaster's own chance of this, stated with the estimate: 55%; the middle value does not contradict the limit.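

In this assay compound 4 gives >= 3200 nM, which is a limit of the assay and not a number. The steps from compound 1, compound 2 and compound 3 to compound 4 cannot be read, because of the limit: the limit of >= 3200 nM in this assay, at which 2 of the 4 values shown sit.

The compounds shown leave open whether ethylamino in place of phenyl on a carbonyl carbon changes the tolerated concentration at all.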